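The compounds below may be only part of what the source reports. "The series", "measured", "known", "first", "only" and "open" are said of these compounds alone.

Three compounds have numbers so far in a functional assay on PC-3 cells (Homo sapiens) for inhibition, read by MTT assay, with a stated time of 72 h; a lower number here means a stronger inhibitor, a higher number a weaker inhibitor:

- compound 1 `FC(F)(F)c1ccc(CSc2nc(N3CCNCC3)cc(C(F)(F)F)n2)cc1` gives 15900 nM
- compound 2 `FC(F)(F)c1ccc(CSc2nc(Sc3ccccn3)cc(C(F)(F)F)n2)cc1` gives 25200 nM
- compound 3 `FC(F)(F)c1ccc(CSc2nc(Sc3nnnn3-c3ccccc3)cc(C(F)(F)F)n2)cc1` gives 45300 nM

Compound 3 at 45300 nM lies within the scatter of compound 2 and beyond the scatter from compound 1, which shows the lower number. Compound 4 `FC(F)(F)c1ccc(CSc2nc(SC3=NCCS3)cc(C(F)(F)F)n2)cc1` differs from compound 3 as follows: a group of 5 heavy atoms (3 carbon, 1 nitrogen, 1 sulfur; one five-membered non-aromatic ring with 2 hetero atoms) in place of a group of 11 heavy atoms (7 carbon, 4 nitrogen; one five-membered aromatic ring with 4 hetero atoms, one six-membered aromatic ring of carbon only), on a sulfur and no other part changes. Among the measured compounds shown here, two measured steps bear on this. The closer one, also a swap on that sulfur, is a 1.8-fold higher number from compound 2 to compound 3 (0.25 log units; within the scatter) and the other is a 1.6-fold higher number from compound 1 to compound 2 (0.20 log units; within the scatter) and neither leaves the scatter. No step beyond the scatter is therefore expected in this assay in either direction. The estimate is a 1.8-fold lower number from compound 3 to compound 4 (0.26 log units; within the scatter) and so stays a modest expected move. For compound 4 the expected value is 25000 nM within an estimated range of 10000 nM to 55000 nM.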

Compound 4, half-maximal inhibitory concentration: 40600 nM
For compound 4 the middle estimate is 1.6-fold (0.21 log units) below the measured one, within the range that was stated.
By their numbers in this assay, from the lowest: compounds 1, 2, 4 and 3 (each within the scatter of the next, the first and the last beyond it).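

In this assay, a group of 5 heavy atoms with a non-aromatic ring replaces the 1-phenyl-1H-tetrazol-5-yl on this sulfur with a 1.1-fold lower number from compound 3 to compound 4 (0.05 log units; within the scatter) and replaces the pyridin-2-yl with a 1.6-fold higher number from compound 2 to compound 4 (0.21 log units; within the scatter) so three quite different groups there stay within the scatter of one another. Set against the piperazin-1-yl group on the aromatic carbon, the same group gives a 2.6-fold higher number from compound 1 to compound 4 (0.41 log units; beyond the scatter) and this modest step is the only new one to leave the scatter. Nothing measured here accounts for these numbers.

Still open, from the compounds shown here alone, is whether a simple amine or a carboxylic acid on this sulfur would leave that scatter. A longer alkyl chain there is equally untested by the compounds shown.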